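The source may report more compounds than this note shows. Statements on the series, on what has been measured and on what is new or still open speak of the compounds shown alone.

In a functional assay on SK-BR-3 cells (Homo sapiens) for cytotoxicity, read by MTT assay, with a stated time of 72 h (on this read-out higher numbers stand for an effect only at larger amounts of compound and lower numbers for an effect already at smaller amounts), three compounds built on one shared core have been measured so far. Compound 1 `Cc1ccc(Nc2cc(-c3ccccc3)oc(=O)c2)cc1` gives 0.09 uM, and compound 2 `COc1ccc(Nc2cc(-c3ccccc3)oc(=O)c2)cc1` gives 0.079 uM; the step of a 1.1-fold lower number from compound 1 to compound 2 (0.06 log units; within the scatter) shows that swapping one small group for another on the outer aromatic ring made no real difference. Compound 3 `O=c1cc(NC2CCCCC2)cc(-c2ccccc2)o1` gives 10.9 uM, the highest of the three numbers, with compound 1 the nearest of the other two and compound 2 the furthest.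

Compound 4 `O=c1cc(Nc2ccc(Br)cc2)cc(-c2ccccc2)o1` differs from compound 3 in one place: 4-bromophenyl in place of cyclohexyl on a nitrogen on an aromatic ring. For the measured compounds named here, the one measured step that speaks to this change is a 120-fold higher number from compound 1 to compound 3 (2.08 log units; beyond the scatter), where an aromatic ring on that nitrogen was replaced by a saturated one and the number rose sharply. Compound 4 goes the opposite way, putting an aromatic ring back in place of the saturated one, so a large drop in the number is expected. Compound 4 is therefore estimated at 0.1 uM, in a range of 0.03 uM to 0.4 uM, which would mean an expected step of a 110-fold lower number from compound 3 to compound 4 (2.04 log units; beyond the scatter).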

Compound 4, concentration for half-maximal effect: 0.4 uM
For compound 4 the middle estimate is 4.0-fold (0.60 log units) below the measured one; the measured number falls inside the stated range.
By their numbers in this assay, from the lowest: compounds 2 and 1 (each within the scatter of the next); then compound 4; then compound 3.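

Putting an aromatic ring back on the nitrogen is again a large change: 4-bromophenyl in place of cyclohexyl gives a 27-fold lower number from compound 3 to compound 4 (1.44 log units; beyond the scatter), the opposite direction to the earlier move from an aromatic ring to a saturated one. What is new is that the group on the outer aromatic ring can also matter, which the swap of methyl for methoxy did not show: bromo in place of methoxy gives a 5.1-fold higher number from compound 2 to compound 4 (0.70 log units; beyond the scatter), and bromo in place of methyl gives a 4.4-fold higher number from compound 1 to compound 4 (0.65 log units; beyond the scatter). No measurement at hand accounts for these differences.

Bromo is the only halogen here, so it remains open whether chloro, a nitrile or a carboxylic acid on that ring would behave like bromo or like methyl and methoxy. Also open, going by these compounds, is how an open chain, such as hexyl, on the nitrogen would compare with cyclohexyl.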